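A few compounds are considered here, and "the series" means these few. Any claim that something is new, unique, unknown or untested is made for them only; others in the source may bear on it.

Measured in a physicochemical assay for solubility, using the shake flask method, measured as kinetic solubility, with a stated time of 2 h, at pH 7.4; a higher number here means a more soluble compound, a lower number a less soluble compound:
compound 1 `CN(Cc1ccccc1)c1cc(C(=O)Nc2ccccc2)ncn1`, reported only as a limit: < 5000 nM
compound 2 `CN(Cc1ccc(C(F)(F)F)cc1)c1cc(C(=O)Nc2ccccc2)ncn1`, reported only as a limit: < 5000 nM
compound 3 `CN(Cc1cccnc1)c1cc(C(=O)Nc2ccccc2)ncn1`: 150000 nM

Compound 1 and compound 2 differ by trifluoromethyl in place of hydrogen on an aromatic carbon. Both values are limits of the assay, so the step is a step that the two limits leave unreadable from compound 1 to compound 2; its size cannot be read, both values sitting at the limit of < 5000 nM in this assay, at which 2 of the 3 values shown sit. The two cores differ by pyridin-3-yl in place of phenyl on a saturated chain carbon bound to a nitrogen on an aromatic ring, which gave an at least 30-fold higher number from compound 1 to compound 3 (1.47 log units; beyond the scatter).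

Compound 4 `CN(Cc1ccc(C(F)(F)F)nc1)c1cc(C(=O)Nc2ccccc2)ncn1`, not yet measured, carries the same kind of change as compound 1 to compound 2: trifluoromethyl in place of hydrogen on an aromatic carbon. The places are not the same word for word: in compound 2 the trifluoromethyl enters on an aromatic carbon of a six-membered aromatic ring of carbon only, para to a large group, whereas in compound 4 it enters on an aromatic carbon of a six-membered aromatic ring with 1 nitrogen, next to the ring nitrogen, para to a large group.

The expectation rests on compound 3 at 150000 nM, with no readable size from a step that the two limits leave unreadable from compound 1 to compound 2 to carry over. The expected step is a 3.8-fold lower number from compound 3 to compound 4 (0.57 log units; beyond the scatter). For compound 4 the estimate is 40000 nM, with the range 8000 nM to 150000 nM.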

Compound 4, solubility: < 5000 nM
Compound 4: only a limit was reported; the forecaster's own chance of this, stated with the estimate: 15%; middle value at least 8.0-fold (0.90 log units) from the limit.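

In this assay, trifluoromethyl in place of hydrogen on an aromatic carbon of the core of compound 3 gave an at least 30-fold lower number from compound 3 to compound 4 (1.47 log units; beyond the scatter), so on this core the change takes a readable number down to the limit. The result for compound 4, < 5000 nM, is a limit of the assay and not a number, so the step has a minimum size only. The same change on the core of compound 1 cannot be read, which leaves the two steps without a comparison of size and shows only that both changes end at one reporting limit, not that the effect carries over in equal measure: the limit of < 5000 nM in this assay, at which 3 of the 4 values shown sit.

Still open, going by these compounds, is how the pyridin-3-yl core behaves with other groups at the same ring carbon, such as a carboxylic acid, an amine or a nitrile, and whether any of them gives a readable number in this assay. Among these compounds, with compound 3 as the only readable number, the series also offers no measured size for any substitution on the phenyl core.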